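The compounds below may be only part of what the source reports. "The series", "measured", "known", "first", "only" and "open" are said of these compounds alone.

Among the measured compounds shown here, in a functional assay on A-375 cells (Homo sapiens) for cytotoxicity, read by MTT assay, with a stated time of 72 h (on this read-out lower numbers stand for stronger inhibition and higher numbers for weaker inhibition), compound 1 (`CN(C)CCCCCn1c2c(c3ccccc31)C(=O)c1c[n+]([O-])c3ccccc3c1C2=O`) gives 560 nM and compound 2 (`O=C1c2c[n+]([O-])c3ccccc3c2C(=O)c2c1c1ccccc1n2CCN1CCCC1`) gives 430 nM, so compound 2 lies within the scatter of the only other measured compound. Compound 3 (`O=C1c2c[n+]([O-])c3ccccc3c2C(=O)c2c1c1ccccc1n2CCCCN1CCNCC1`) carries 2-(piperazin-1-yl)ethyl in place of pyrrolidin-1-yl on a saturated chain carbon, two bonds along the chain from an aromatic nitrogen. For the measured compounds named here, the one measured step at this place, a 1.3-fold lower number from compound 1 to compound 2 (0.11 log units; within the scatter), stayed within the scatter, so no step beyond the scatter is expected. The expected change in this assay is a 1.1-fold higher number from compound 2 to compound 3 (0.05 log units; within the scatter). For compound 3 the estimated value is 480 nM, with an expected range of 170 nM to 1400 nM.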

Compound 3, half-maximal inhibitory concentration: 460 nM
Beside the measured number, compound 3's estimate is 1.0-fold (0.02 log units) above it; measured number inside the range.
By their numbers in this assay, from the lowest: compounds 2, 3 and 1 (each within the scatter of the next).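

In this assay, the entering group brings a six-membered ring with 2 hetero atoms and 1 hydrogen-bond donor, yet the change gives a 1.1-fold higher number from compound 2 to compound 3 (0.03 log units; within the scatter). Read at the other cut, piperazin-1-yl in place of (dimethylamino)methyl gives a 1.2-fold lower number from compound 1 to compound 3 (0.09 log units; within the scatter), so all three end groups at this place now stand within the scatter of one another. Nothing available here accounts for this.

Going by these compounds, whether a chain ending in a carboxylic acid or a plain methyl group, with no amine at all, would stay within the scatter remains open.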